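Swapping amino for hydroxy: what stability to expect

A few compounds are considered here, and "the series" means these few. Any claim that something is new, unique, unknown or untested is made for them only; others in the source may bear on it.

Values in an ADME assay on microsomes from liver (Homo sapiens) for metabolic stability, with a stated time of 10 min; a higher number here means that more of the compound is left, a lower number that less of the compound is left:
- Compound 1 `Cc1c(Cl)cccc1Oc1cccn2c(C34CCC(CC3)C4)nnc12`: 69%
- Compound 2 `COC1(c2nnc3c(Oc4cccc(Cl)c4C)cccn23)CCCCCC1`: < 1% (a limit)
- Compound 3 `Cc1c(Cl)cccc1Oc1cccn2c(C34CCC(N)(CC3)CC4)nnc12`: "not determined" (no result reported)

Compound 3 has no number to start from, as its result reads "not determined" (no result reported). In compound 4 `Cc1c(Cl)cccc1Oc1cccn2c(C34CCC(O)(CC3)CC4)nnc12`, hydroxy takes the place of amino on a saturated ring carbon: hydroxy in place of amino on a saturated ring carbon. Going by the values given here, the only measured step, a number at least 68 percentage points lower from compound 1 to compound 2 (beyond the scatter), exchanges a whole group rather than this one, and it shows how far values can spread on the shared core. Without a number for compound 3, no size or direction can be expected for this step. The expectation therefore leans on compound 1 at 69%, whose group, like that of compound 4, holds two non-aromatic rings. For compound 4 the estimated value is 65%, with an expected range from 30% to 90%.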

Compound 4, percent of the compound remaining: 100%
For compound 4 the middle estimate is 35 percentage points below the measured one; measured number outside the range, above it.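

Against the other two groups on the shared core, the hydroxy-bearing group of compound 4 stands out in this assay, with a number 31 percentage points higher from compound 1 to compound 4 (beyond the scatter) and a number at least 99 percentage points higher from compound 2 to compound 4 (beyond the scatter). So hydroxy on this saturated ring carbon, in a six-membered ring that is part of a fused or bridged system of two rings, goes with a well-kept compound. The second step rests on a limit: the limit of < 1% in this assay, at which 1 of the 4 values shown sits.

The swap of amino for hydroxy itself cannot be read, as compound 3 has no number. On these data alone, how a fluorine atom or a carboxylic acid at this ring carbon would fare stays open.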